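Piperazine amides of the shared core: ketone to aryl ether

This account rests on a few compounds, and the source may have more. Where it says the series, first, only, none or still open, it means among the compounds named here.

Measured so far:
compound 1 `CC(C)C[C@H](N)c1ccccc1N1CCN(C(=O)[C@H](C)Cc2ccc(Cl)cc2F)CC1`, 67 nM
compound 2 `CC(C)C[C@H](N)c1cc(Cl)ccc1N1CCN(C(=O)C(C)Cc2ccc(Cl)cc2)CC1`, 67 nM
compound 3 `CC(C)C[C@H](N)c1cc(C(F)(F)F)ccc1N1CCN(C(=O)CC(C)C(=O)c2ccc(Cl)cc2)CC1`, 1100 nM

In an assay on HEK293 cells for displacement of a labelled ligand from Melanocortin receptor 4 (Homo sapiens) (a lower number here means a stronger inhibitor, a higher number a weaker inhibitor), compound 3 gives the highest of the three numbers, beyond the scatter from both compound 1 and compound 2, whose values are within the scatter of each other. Compound 3 carries a ketone in its acyl chain, which compound 1 and compound 2 do not.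

Compound 4 `Cc1ccc(OCC(=O)N2CCN(c3ccc(C(F)(F)F)cc3[C@@H](N)CC(C)C)CC2)c(C)c1` is not yet measured. It differs from compound 3 in one place: 2,4-dimethylphenoxy in place of 1-((4-chlorophenyl)carbonyl)ethyl on a saturated chain carbon bound to a carbonyl carbon. Among the measured compounds shown here, no step between measured compounds matches this change, so the expectation rests on compound 3 alone. From compound 3 to compound 4 a step of a 1.8-fold lower number from compound 3 to compound 4 (0.26 log units; within the scatter) is expected in this assay, downward and of modest size, near the edge of the scatter. Compound 4 is therefore estimated at 600 nM, within 150 nM to 2500 nM.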

Compound 4, inhibition constant: 4000 nM
Compound 4: the middle estimate sits 6.7-fold (0.82 log units) below what was measured, and the stated range ends below it.
By their numbers in this assay, from the lowest: compounds 1 and 2 (each within the scatter of the next); then compound 3; then compound 4.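

In this assay, the place on a saturated chain carbon bound to a carbonyl carbon is sensitive to what it carries: 2,4-dimethylphenoxy in place of 1-((4-chlorophenyl)carbonyl)ethyl gives a 3.6-fold higher number from compound 3 to compound 4 (0.56 log units; beyond the scatter) with the rest of the molecule unchanged. Both groups count one carbon-only aromatic ring and one hydrogen-bond acceptor, so those counts alone do not keep the number level. No data shown here bear on the cause of this step.
A single pair cannot separate the effect of the ether oxygen from that of the two methyl groups or the lost chlorine. As far as these compounds go, how a plain phenoxy, a 4-chlorophenoxy or a carboxylic acid would read at this place remains open.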